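Extending the hydroxycarbamoyl chain in compound 3

The source may report more compounds than this note shows. Statements on the series, on what has been measured and on what is new or still open speak of the compounds shown alone.

Within the data shown here, in a functional assay on cells (Homo sapiens) for inhibition, read by MTT assay, with a stated time of 48 h (on this read-out higher numbers stand for weaker inhibition and lower numbers for stronger inhibition), compound 2 (`O=C(CCCOc1no[n+]([O-])c1S(=O)(=O)c1ccccc1)NO`) gives 22000 nM as the only number available so far. For compound 1 (`O=S(=O)(c1ccccc1)c1c(OCCCCCCO)no[n+]1[O-]`), which shares the core, the entry in this assay reads "not determined" (no result reported) and offers no comparison, so compound 2 cannot yet be ranked against anything.

Compound 3 (`O=C(CCCCOc1no[n+]([O-])c1S(=O)(=O)c1ccccc1)NO`) departs from compound 2 in its side chain. The change is (hydroxycarbamoyl)methyl in place of hydroxycarbamoyl on a saturated chain carbon, three bonds along the chain from an oxygen on an aromatic ring and amounts to (hydroxycarbamoyl)methyl in place of hydroxycarbamoyl on a saturated chain carbon, three bonds along the chain from an oxygen on an aromatic ring. Cut further out, it reads 3-(hydroxycarbamoyl)propyl to 4-(hydroxycarbamoyl)butyl.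

Among the measured compounds shown here, no measured step exists to calibrate this change. With compound 2 at 22000 nM as the sole anchor, a small shift toward stronger inhibition in this assay is expected, close to the edge of the usual scatter. The estimate amounts to a 1.8-fold lower number from compound 2 to compound 3 (0.26 log units; within the scatter) in that direction. For compound 3 the expected value is 12000 nM with an estimated range from 3500 nM to 40000 nM as the likely span of the measurement.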

Compound 3, half-maximal inhibitory concentration: 4300 nM
Compound 3: the middle estimate sits 2.8-fold (0.45 log units) above what was measured, within the range that was stated.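

In this assay, (hydroxycarbamoyl)methyl in place of hydroxycarbamoyl on a saturated chain carbon, three bonds along the chain from an oxygen on an aromatic ring, gives a 5.1-fold lower number from compound 2 to compound 3 (0.71 log units; beyond the scatter), and this first readable step on the shared core lies beyond the usual scatter. Among these compounds, it shows that this read-out responds to the length of the chain carrying the hydroxycarbamoyl group, with 4-(hydroxycarbamoyl)butyl giving stronger inhibition than 3-(hydroxycarbamoyl)propyl, which the single number for compound 2 and the empty entry for compound 1 could not show. The data at hand offer no measurement that accounts for this shift.

On these data alone, with only these chain lengths compared, it remains open whether a longer chain ending in hydroxycarbamoyl would extend the trend toward stronger inhibition, hold it level or reverse it. It is equally open whether the hydroxycarbamoyl group itself is needed at the end of the chain, since neither a carboxylic acid nor a primary amide in its place on the 4-carbon-named butyl chain appears among the compounds shown.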